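The source may hold more compounds than are shown below. What is called first, only, known or untested is meant among the compounds shown, and "the series" means these compounds.

Working notes on the series.

Going by the values given here, compound 1, `O=C1N/C(=N/c2ccccc2)S/C1=C\c1ccccn1`, is one of two compounds so far measured in a functional assay on the whole organism (strain Wistar) for inhibition, with Rattus norvegicus as the target, read by paw edema, with stated times of 30 min and 120 min, at a dose of 10 mg/kg by the oral route; on this read-out higher numbers stand for more inhibition at the one dose given (going by the name of the read-out) and lower numbers for less inhibition. In this assay compound 1 gives 26.2%, the lower of the two numbers recorded. The other measured compound, compound 2, `O=C1N/C(=N\Nc2ccc([N+](=O)[O-])cc2[N+](=O)[O-])S/C1=C\c1ccccn1`, gives 56.5% in this assay, a number that lies beyond the usual scatter above that of compound 1. No single-point change links compound 1 and compound 2, so their two values are read side by side only, not as a step.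

The next compound to be measured is compound 3, `O=C1N/C(=N/c2ccccc2Cl)S/C1=C\c1ccccn1`. It differs from compound 1 in one place: chloro in place of hydrogen on an aromatic carbon. Nothing in the measured set shows how a change of this kind plays out in this assay, so no step size can be drawn from the data. The expectation for the step from compound 1 to compound 3 in this assay is a small one, upward if anything, and most likely within the scatter: a number 5.8 percentage points higher from compound 1 to compound 3 (within the scatter). Compound 3 is therefore expected to give about 32% in this assay, with a range from 18% to 46%.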

Compound 3, a percentage reported as inhibition, in the whole organism at one dose (the size of the read-out at that dose, not a potency): 26.2%
The estimate for compound 3 lay 5.8 percentage points above the measured number; the range from low to high includes it.
By their numbers in this assay, from the lowest: compounds 1 and 3 (each within the scatter of the next); then compound 2.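

The step gives the series its first single-point reading: with chloro in place of hydrogen on an aromatic carbon, ortho to a large group, this assay shows no change at the digits printed from compound 1 to compound 3 (within the scatter) at the one dose given. Phenyl and 2-chlorophenyl therefore read alike here, so this position carries a chlorine atom with no measurable effect on the read-out, something that the two earlier compounds could not show since no single-point change linked them. Going by these compounds alone, nothing on hand accounts for this result, and the step's size is the only information it gives about this change.

Still open, on these data alone, is whether this holds for other groups at this position, such as a methoxy group, an amine, a carboxylic acid or a longer chain, any of which might move the read-out beyond the scatter where chloro does not. Also open, as far as these compounds go, is how chloro reads on the other carbons of the same ring, and whether the match between compound 1 and compound 3 holds at other doses, since a single dose cannot settle that.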